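Swapping a Ring on the Chain of Compound 2

The compounds below may be only part of what the source reports. "The series", "measured", "known", "first", "only" and "open" are said of these compounds alone.

Compound 1 `COC(=O)CC/C=C\CC[C@H]1C(=O)C[C@@H](O)[C@@H]1/C=C/C[C@@](C)(O)/C=C/C1CCCC1` gives 1.95 mg/kg
Compound 2 `COC(=O)CC/C=C\CC[C@H]1C(=O)C[C@@H](O)[C@@H]1/C=C/C[C@@](C)(O)/C=C/C1=CCCCC1` gives > 3.16 mg/kg

In a functional assay on the whole organism with Rattus norvegicus as the target (a lower number here means that less compound is needed, a higher number that more compound is needed for the effect), compound 2 stands at > 3.16 mg/kg as a limit of the assay, not a number. Compound 3 `COC(=O)CC/C=C\CC[C@H]1C(=O)C[C@@H](O)[C@@H]1/C=C/C[C@@](C)(O)/C=C/C1CCC1` carries cyclobutyl in place of cyclohex-1-en-1-yl on a double-bonded chain carbon bound to a double-bonded chain carbon. Within the data shown here, one measured step bears on this: an at least 1.6-fold higher number from compound 1 to compound 2 (0.20 log units; that floor lies within the scatter) whose floor lies within the scatter. It brought in the cyclohex-1-en-1-yl that compound 3 gives up, so a modest move to a lower number in this assay is expected. The expected change is an at least 1.2-fold lower number from compound 2 to compound 3 (0.10 log units; that floor lies within the scatter) by this estimate. Compound 3 is expected near 2.5 mg/kg with an estimated range from 0.8 mg/kg to 8 mg/kg for now.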

Compound 3, dose for half-maximal effect: 0.53 mg/kg
Compound 3: middle estimate off by 4.7-fold (0.67 log units), on the high side; the measured number lies below the stated range.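

The earlier step left it unclear whether the ring on this double-bonded chain carbon matters, but it clearly does: in this assay, cyclobutyl in place of cyclopentyl gives a 3.7-fold lower number from compound 1 to compound 3 (0.57 log units; beyond the scatter). Cyclobutyl in place of cyclohex-1-en-1-yl gives an at least 5.9-fold lower number from compound 2 to compound 3 (0.77 log units; beyond the scatter). Compound 2 stands at a limit of the assay, not a number: the limit of > 3.16 mg/kg in this assay, at which 1 of the 3 values shown sits.

From the compounds shown here alone, whether the number would fall further with a cyclopropyl ring, or change with an open isopropyl group or a phenyl ring at this place, stays open.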